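The source may hold more compounds than are shown below. What is called first, only, known or untested is meant among the compounds shown, and "the series" means these compounds.

Three compounds share one core and differ only in the group attached to the sulfonyl sulfur. Compound 1 `Cc1ccc(S(=O)(=O)Nc2ccc3oc(-c4ccccc4)nc3c2)cc1` carries a 4-methylphenyl there, compound 2 `Cc1ccccc1S(=O)(=O)Nc1ccc2oc(-c3ccccc3)nc2c1` a 2-methylphenyl, and compound 3 `O=S(=O)(Nc1ccc2oc(-c3ccccc3)nc2c1)c1ccccc1O` a 2-hydroxyphenyl. In an assay on cells for inhibition of HSP60/HSP10 (Homo sapiens), with a stated time of 60 min (on this read-out lower numbers stand for stronger inhibition and higher numbers for weaker inhibition), compound 1 reaches only the limit of the assay, > 100000 nM. Compound 2 likewise gives only the limit, > 100000 nM. Among the measured compounds shown here, compound 3 is the one compound with an actual number, 85000 nM, which is still a weak result. Two of the three results sit at the limit of > 100000 nM in this assay, at which 2 of the 3 values shown sit, so the step that the two limits leave unreadable from compound 1 to compound 2 cannot be read. The steps of an at least 1.1-fold lower number from compound 1 to compound 3 (0.07 log units; that floor lies within the scatter) and an at least 1.1-fold lower number from compound 2 to compound 3 (0.07 log units; that floor lies within the scatter) are only floors that lie within the usual scatter, so compound 3 cannot be called clearly stronger than the other two.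

Compound 4 `CS(=O)(=O)Nc1ccc2oc(-c3ccccc3)nc2c1` changes the same place once more: methyl in place of 2-hydroxyphenyl on a sulfonyl sulfur. For the measured compounds named here, none of the measured steps removes the aromatic group from the sulfonyl sulfur, so no step bears directly on this change; all three measured compounds, each with an aromatic group there, are weak or beyond the limit. Compound 4 is therefore expected to remain weak, the expected step being a 1.5-fold higher number from compound 3 to compound 4 (0.18 log units; within the scatter), that is, a somewhat higher number. The estimate for compound 4 is 130000 nM, with a range from 40000 nM to 400000 nM, and a good chance that only the limit is reported.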

Compound 4, half-maximal inhibitory concentration: > 100000 nM
Compound 4 was reported as a limit (the forecaster's own chance of this, stated with the estimate: 65%); the middle value lies beyond the limit too.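

The step to methyl on the sulfonyl sulfur is an at least 1.1-fold higher number from compound 3 to compound 4 (0.07 log units; that floor lies within the scatter), so in this assay the loss of the 2-hydroxyphenyl brings no clear change in either direction. Among the compounds shown here, compound 4 is the first compound here with no ring on the sulfonyl sulfur, and it shows no inhibition that can be read as a number, so replacing the aromatic group with methyl has not uncovered any strength at this place. The steps from compound 1 and from compound 2 to compound 4 cannot be read, since limits stand at both ends of each: the limit of > 100000 nM in this assay, at which 3 of the 4 values shown sit.

With aromatic groups and methyl alike giving a limit or a weak number, the compounds shown do not tell whether any group on the sulfonyl sulfur can bring a clear gain in this core. A longer chain such as butyl, or a ring-bearing group with an amine or a carboxylic acid on it, remains untested among these compounds, as does any change to the phenyl group on the other end of the shared core.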